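The compounds below may be only part of what the source reports. "The series", "measured", "known", "first", "only" and "open" are said of these compounds alone.

In a functional assay on HeLa cells (Homo sapiens) for antiproliferative activity, read by MTT assay, with a stated time of 48 h (on this read-out lower numbers stand for stronger inhibition and higher numbers for weaker inhibition), compound 3 (`CCN(CC)CCn1c(N)c(-c2nc3cc(Cl)ccc3[nH]2)c2nc(C#N)c(C#N)nc21`) gives > 50000 nM, a limit and not a number. Going by the values given here, the series so far holds (the limit of > 50000 nM in this assay, at which 1 of the 3 values shown sits).

Compound 4 (`CN(C)CCCCn1c(N)c(-c2nc3cc(Cl)ccc3[nH]2)c2nc(C#N)c(C#N)nc21`) has the same atoms joined differently: 2-(dimethylamino)ethyl in place of diethylamino on a saturated chain carbon, two bonds along the chain from an aromatic nitrogen. This reads as 2-(diethylamino)ethyl giving way to 4-(dimethylamino)butyl. Among the compounds with values here, no measured step covers this change.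

The nearest data are compound 1 (`CN(C)CCCCn1c(N)c(-c2nc3ccccc3s2)c2nc(C#N)c(C#N)nc21`) and compound 2 (`CN(C)CCCCn1c(N)c(-c2nc3ccccc3n2C)c2nc(C#N)c(C#N)nc21`), which carry the 4-(dimethylamino)butyl chain of compound 4. Compound 1 gives 18700 nM and compound 2 gives 460 nM. Both are numbers rather than a limit, which points to a lower number for compound 4, though only these two compounds support it. Their difference, a 41-fold lower number from compound 1 to compound 2 (1.61 log units; beyond the scatter), is large and comes from the group on an aromatic carbon, where compound 4 matches neither, so the range must stay wide.

The expected change is an at least 12-fold lower number from compound 3 to compound 4 (1.09 log units; beyond the scatter), towards a lower number. For compound 4 the estimated value is 4000 nM, with an expected range of 500 nM to 30000 nM.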

Compound 4, half-maximal inhibitory concentration: 3120 nM
For compound 4 the middle estimate is 1.3-fold (0.11 log units) above the measured one; low and high end bracket the measured number.
By their numbers in this assay, from the lowest: compound 2; then compound 4; then compound 1. At a limit, above all of these: compound 3.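

In this assay, the change from 2-(diethylamino)ethyl to 4-(dimethylamino)butyl, with the 5-chloro-1H-benzimidazol-2-yl group held fixed, now has a step of its own: an at least 16-fold lower number from compound 3 to compound 4 (1.20 log units; beyond the scatter). The value of compound 3 is a limit and not a number: the limit of > 50000 nM in this assay, at which 1 of the 4 values shown sits.

With the 4-(dimethylamino)butyl chain held fixed, 5-chloro-1H-benzimidazol-2-yl places compound 4 between the other two groups, with a 6.8-fold higher number from compound 2 to compound 4 (0.83 log units; beyond the scatter) and a 6.0-fold lower number from compound 1 to compound 4 (0.78 log units; beyond the scatter).

The chain step combines chain length with the change in the amine, and the compounds shown do not separate the two; a 4-(diethylamino)butyl chain on the same core would do so. Also open, from the compounds shown here alone, is what the chlorine contributes, which the unsubstituted 1H-benzimidazol-2-yl group would show.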